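The source may report more compounds than this note shows. Statements on the series, on what has been measured and on what is new or still open speak of the compounds shown alone.

Compound 1 `CCN1CCN(c2ccc(Nc3ncc(Cl)c(Nc4ccccc4C)n3)nc2)CC1`: > 100000 nM
Compound 2 `Cc1ccccc1Nc1nc(Nc2ccc(N3CCCCC3)cn2)ncc1Cl`: > 100000 nM
Compound 3 `CCN1CCN(c2ccc(Nc3ncc(Cl)c(Nc4ccccc4C)n3)cc2)CC1`: 3040 nM

In a functional assay on MDA-MB-231 cells (Homo sapiens) for inhibition, read by CCK-8 assay, with a stated time of 48 h (a higher number here means a weaker inhibitor of growth, a lower number a stronger inhibitor of growth), compound 1 gives > 100000 nM, which is a limit of the assay and not a number. Compound 2 likewise gives > 100000 nM, again a limit. Going by the values given here, compound 3 is the one compound with a real number, giving 3040 nM in this assay. The change piperidin-1-yl in place of 4-ethylpiperazin-1-yl on an aromatic carbon therefore yields a step that the two limits leave unreadable from compound 1 to compound 2, because both ends sit at the limit of > 100000 nM in this assay, at which 2 of the 3 values shown sit. How the core of compound 3 differs from the core of compound 1 is not broken down here.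

Compound 4 `Cc1ccccc1Nc1nc(Nc2ccc(N3CCCCC3)cc2)ncc1Cl` has not been measured in this assay. It differs from compound 3 by piperidin-1-yl in place of 4-ethylpiperazin-1-yl on an aromatic carbon. This is the same kind of change as that from compound 1 to compound 2, but the place is not the same: there the group sits on a six-membered aromatic ring with 1 nitrogen, two atoms from the ring nitrogen, here on a six-membered aromatic ring of carbon only. The measured pair gives no readable size, so the expected step of a 2.6-fold higher number from compound 3 to compound 4 (0.42 log units; beyond the scatter) rests only on the scatter around the value of compound 3, 3040 nM. Compound 4 is estimated at 8000 nM, between 1500 nM and 60000 nM.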

Compound 4, concentration for 50% growth inhibition: 19900 nM
Compound 4: middle estimate off by 2.5-fold (0.40 log units), on the low side, within the range that was stated.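

In this assay, piperidin-1-yl in place of 4-ethylpiperazin-1-yl on a six-membered aromatic ring of carbon only gives a 6.5-fold higher number from compound 3 to compound 4 (0.82 log units; beyond the scatter), which means weaker growth inhibition by a margin beyond the scatter. The same change on the core of compound 1 cannot be read, because both ends of that step are limits of the assay and not numbers: the limit of > 100000 nM in this assay, at which 2 of the 4 values shown sit. The change therefore has a measured size on one core only, so these data neither confirm nor rule out a step of similar size on the other core.

The compounds shown leave open how a morpholine ring or a simple dimethylamino group would compare with these two groups on the same carbon. They also leave open whether the ethyl group itself matters, which a piperazine ring carrying a methyl group or only a hydrogen in its place could help to settle.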